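The compounds below may be only part of what the source reports. "The series", "measured", "known", "first", "only" and "open" are said of these compounds alone.

In a functional assay on HuTu80 cells (Homo sapiens) for cytotoxicity, read by MTT assay, with a stated time of 72 h (on this read-out higher numbers stand for an effect only at larger amounts of compound and lower numbers for an effect already at smaller amounts), compound 1 `O=C1/C(=C\c2cccc(Oc3ccccc3)c2)c2ccccc2N1c1c(Cl)cccc1Cl` gives 10 ug/mL and compound 2 `O=C1/C(=C\c2cccc(Br)c2)c2ccccc2N1c1c(Cl)cccc1Cl` gives 7 ug/mL; the step of a 1.4-fold lower number from compound 1 to compound 2 (0.15 log units; within the scatter) lies within the scatter. For compound 3 `O=C1/C(=C\c2ccccc2Cl)c2ccccc2N1c1c(Cl)cccc1Cl` this assay reports only a limit, > 100 ug/mL. The step of an at least 14-fold higher number from compound 2 to compound 3 (1.15 log units; beyond the scatter) is large. Of the two numbers shown, compound 2 has the lower one, with compound 1 nearest and within the scatter. Compound 4 `O=C1/C(=C\c2ccccc2[N+](=O)[O-])c2ccccc2N1c1c(Cl)cccc1Cl` differs from compound 2 in that (2-nitrophenyl in place of 3-bromophenyl on a double-bonded chain carbon bound to a double-bonded ring carbon). The step from compound 2 to compound 3 bears on this change, since there too 3-bromophenyl left the same place, so one expects a large rise in this assay, an 8.6-fold higher number from compound 2 to compound 4 (0.93 log units; beyond the scatter), perhaps again only a limit. Compound 4 is estimated at 60 ug/mL, between 15 ug/mL and 150 ug/mL.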

Compound 4, concentration for half-maximal effect: 10 ug/mL
For compound 4 the middle estimate is 6.0-fold (0.78 log units) above the measured one; measured number outside the range, below it.
By their numbers in this assay, from the lowest: compounds 2, 1 and 4 (each within the scatter of the next). At a limit, above all of these: compound 3.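

Leaving 3-bromophenyl at this place does not by itself bring the large rise seen with compound 3, for 2-nitrophenyl is taken up there without a change beyond the scatter in this assay (a 1.4-fold higher number from compound 2 to compound 4 (0.15 log units; within the scatter)). Nitro in place of chloro on an aromatic carbon instead restores the lower numbers (an at least 10-fold lower number from compound 3 to compound 4 (1.00 log units; beyond the scatter)), so here the rise goes with the chloro group and not with the departure of 3-bromophenyl. Going by these compounds, whether an amine or a carboxylic acid on that aromatic carbon would follow nitro or chloro stays open. The full size of the gap to compound 3 also stays open, since its value is only a limit: the limit of > 100 ug/mL in this assay, at which 1 of the 4 values shown sits.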